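A few compounds are considered here, and "the series" means these few. Any claim that something is new, unique, unknown or untested is made for them only; others in the source may bear on it.

In a functional assay on MDA-MB-231 cells (Homo sapiens) for inhibition, read by CCK-8 assay, with a stated time of 48 h (on this read-out lower numbers stand for stronger inhibition of growth and higher numbers for weaker inhibition of growth), the measured compounds read:

Compound 1 `Cc1ccc(Nc2ncc(Cl)c(Nc3ccccc3C)n2)cc1`: > 100000 nM (a limit)
Compound 2 `Cc1ccccc1Nc1nc(NCc2ccccc2)ncc1Cl`: > 100000 nM (a limit)
Compound 3 `Cc1ccccc1Nc1nc(Nc2cc(Cl)ccn2)ncc1Cl`: 52400 nM

Compound 1 has no number, only (the limit of > 100000 nM in this assay, at which 2 of the 3 values shown sit). Compound 4 `Cc1ccccc1Nc1nc(Nc2ccc(N3CCCN(C)CC3)cc2)ncc1Cl` carries 4-methyl-1,4-diazepan-1-yl in place of methyl on an aromatic carbon of compound 1, para to a large group: 4-methyl-1,4-diazepan-1-yl in place of methyl on an aromatic carbon.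

For the measured compounds named here, no measured step involves this group. The nearest steps exchange the whole substituent on a nitrogen. Going by the values given here, the first is a step that the two limits leave unreadable from compound 1 to compound 2. The others are an at least 1.9-fold lower number from compound 1 to compound 3 (0.28 log units; that floor lies within the scatter) and an at least 1.9-fold lower number from compound 2 to compound 3 (0.28 log units; that floor lies within the scatter).

These steps set no size for the change, so the expectation is loose. Compound 3 gives 52400 nM, which shows that the shared core can return a number in this assay. A step towards a lower number is therefore expected, of moderate size and with wide uncertainty. The estimated step is an at least 10-fold lower number from compound 1 to compound 4 (1.00 log units; beyond the scatter). For compound 4 the expected value is 10000 nM, with an estimated range of 2000 nM to 60000 nM.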

Compound 4, concentration for 50% growth inhibition: 6390 nM
Compound 4: the middle estimate sits 1.6-fold (0.19 log units) above what was measured, within the range that was stated.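

In this assay, for the compounds shown here, 4-methyl-1,4-diazepan-1-yl in place of methyl on an aromatic carbon, para to a large group, gives the first step beyond the scatter (an at least 15-fold lower number from compound 1 to compound 4 (1.19 log units; beyond the scatter)). Going by these compounds alone, the earlier exchanges of the whole substituent on a nitrogen gave no such step, so this position on the ring can carry a change that clearly shifts the read-out. The size is only a floor, since compound 1 has a limit and not a number: the limit of > 100000 nM in this assay, at which 2 of the 4 values shown sit.

The compounds shown leave open whether the seven-membered ring is needed, or whether 4-methylpiperazin-1-yl, morpholine or an open-chain dimethylamino group in the same place would give a similar number. They also leave open what the methyl on the ring nitrogen contributes, which a hydrogen or an ethyl group there could test.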